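Dropping one trifluoromethyl from a diaryl urea

A few compounds are considered here, and "the series" means these few. Any claim that something is new, unique, unknown or untested is made for them only; others in the source may bear on it.

Measured so far:
compound 1 `COc1cc(-c2nn(-c3cccc(NC(=O)Nc4cc(C(F)(F)F)cc(C(F)(F)F)c4)c3)cc2-c2ccncc2)ccc1Cl`: 715 nM
compound 2 `O=C(Nc1cccc(-n2cc(-c3ccncc3)c(-c3ccc(Cl)c(O)c3)n2)c1)Nc1ccc(Cl)c(Cl)c1`: 1460 nM

Of the compounds shown here, two sharing a common core have been tested in a functional assay on SW-620 cells (Homo sapiens) for inhibition, read by sulforhodamine B assay, with a stated time of 48 h; a higher number here means a weaker inhibitor of growth, a lower number a stronger inhibitor of growth. Compound 1 gives 715 nM, and compound 2 gives 1460 nM; compound 1 thus holds the lower of the two numbers, and the gap between them lies beyond the scatter.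

Compound 3 `COc1cc(-c2nn(-c3cccc(NC(=O)Nc4cccc(C(F)(F)F)c4)c3)cc2-c2ccncc2)ccc1Cl` has not yet been measured. It differs from compound 1 in a single place: hydrogen in place of trifluoromethyl on an aromatic carbon. The change sits on an aromatic carbon of a six-membered aromatic ring of carbon only, meta to the trifluoromethyl group that remains.

Among the measured compounds shown here, no measured step of this kind is at hand, so the expectation rests on compound 1 alone. A modest step toward a weaker inhibitor of growth, likely within the scatter, is expected: a 1.4-fold higher number from compound 1 to compound 3 (0.15 log units; within the scatter). Compound 3 is therefore estimated at 1000 nM, with a range from 400 nM to 2500 nM.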

Compound 3, concentration for 50% growth inhibition: 1230 nM
For compound 3 the middle estimate is 1.2-fold (0.09 log units) below the measured one; low and high end bracket the measured number.
By their numbers in this assay, from the lowest: compounds 1, 3 and 2 (each within the scatter of the next, the first and the last beyond it).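

In this assay, among the compounds shown here, putting hydrogen in place of trifluoromethyl on this aromatic carbon gives a 1.7-fold higher number from compound 1 to compound 3 (0.24 log units; within the scatter) and is the only single-place step available so far. It shows that, with the other trifluoromethyl group kept and the shared core unchanged, this trifluoromethyl can be lost without a difference that stands clear of the scatter. Nothing at hand explains the size of this step.

The compounds shown leave open whether an amine, a carboxylic acid or a methoxy group on this same carbon would also stay within the scatter of compound 1. They also leave open what happens when the remaining trifluoromethyl group is replaced by hydrogen, so that the ring of the urea carries neither group.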